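The source may hold more compounds than are shown below. What is called first, only, known or untested is meant among the compounds shown, and "the series" means these compounds.

In a functional assay on SW480 cells (Homo sapiens) for antiproliferative activity, read by sulforhodamine B assay, with a stated time of 48 h (a higher number here means a weaker inhibitor, a lower number a stronger inhibitor), compound 1 `COc1cccc(/C=C/C(=O)/C=C(O)/C=C/c2cccc(OC)c2OC)c1OC` gives 12100 nM and compound 2 `COc1ccc(OC)c(/C=C/C(=O)/C=C(O)/C=C/c2cc(OC)ccc2OC)c1` gives 15600 nM. Compound 3 `COc1cccc(/C=C/C(=O)C(=Cc2ccc(F)cc2)C(=O)/C=C/c2cccc(OC)c2OC)c1OC` gives 1040 nM, the lowest of the three numbers and beyond the scatter from both others. Compound 4 `COc1cc(C=C(C(=O)/C=C/c2cccc(OC)c2OC)C(=O)/C=C/c2cccc(OC)c2OC)ccc1O` is still unmeasured. It carries 4-hydroxy-3-methoxyphenyl in place of 4-fluorophenyl on a double-bonded chain carbon bound to a double-bonded chain carbon. Within the data shown here, no measured pair differs in one place only, so the data give no direct guide to the size of this change. The expected step, a 1.4-fold higher number from compound 3 to compound 4 (0.16 log units; within the scatter), leans towards a slightly weaker inhibitor and stays within the scatter. For compound 4 the estimated value is 1500 nM, with an expected range from 550 nM to 4500 nM.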

Compound 4, half-maximal inhibitory concentration: 430 nM
For compound 4 the middle estimate is 3.5-fold (0.54 log units) above the measured one; the measured number lies below the stated range.
By their numbers in this assay, from the lowest: compound 4; then compound 3; then compounds 1 and 2 (each within the scatter of the next).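

In this assay, among these compounds, the double-bonded chain carbon bound to a double-bonded chain carbon responds to a change of its aryl group: 4-hydroxy-3-methoxyphenyl in place of 4-fluorophenyl gives a 2.4-fold lower number from compound 3 to compound 4 (0.38 log units; beyond the scatter), the only single-place comparison. At this position, then, 4-fluorophenyl is not needed to reach the lower numbers. Nothing at hand accounts for the step. The compounds shown do not separate the contribution of the hydroxy group from that of the methoxy group. Also open, on these data alone, is how an amine or a carboxylic acid at this place would read in this assay.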